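The compounds below may be only part of what the source reports. "The series", "measured", "known", "first", "only" and "open" are said of these compounds alone.

The series shares one core, carried in compound 1 `Cc1ccsc1/C=C(/SCc1ccc(Cl)cc1)C(=O)c1ccc(Br)cc1`, compound 2 `Cc1ccsc1/C=C(/SCc1ccc(Cl)cc1)C(=O)c1ccc(Cl)cc1` and compound 3 `Cc1ccsc1/C=C(/SCc1ccc(F)cc1)C(=O)c1ccc(Cl)cc1`, all three run in a functional assay on DU-145 cells (Homo sapiens) for inhibition, read by trypan blue exclusion, with a stated time of 96 h; a higher number here means a weaker inhibitor of growth, a lower number a stronger inhibitor of growth. Compound 1 gives 25000 nM, compound 2 gives 50000 nM and compound 3 gives 50000 nM. Compound 2 stands level with compound 3 at the digits shown, and together those two hold the highest numbers of the three; the step of a 2.0-fold higher number from compound 1 to compound 2 (0.30 log units; within the scatter) and the step of no change at the digits printed from compound 2 to compound 3 (within the scatter) both lie within the scatter, so nothing in these three separates the compounds. Both measured steps concern a halogen swap on an aromatic carbon, and neither touches the group on the double-bonded chain carbon.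

Compound 4 `CSc1ccc(/C=C(/SCc2ccc(Cl)cc2)C(=O)c2ccc(Cl)cc2)cc1` has not yet been run in this assay. It differs from compound 2 in one place: 4-(methylsulfanyl)phenyl in place of 3-methylthiophen-2-yl on a double-bonded chain carbon bound to a double-bonded chain carbon. Among the compounds with values here, no measured step bears on a change of this kind, so no direction can be read from the numbers so far. On that footing the expected step is no change at the digits printed from compound 2 to compound 4 (within the scatter), with a wide range to cover the untested change. Compound 4 is therefore estimated at 50000 nM, between 15000 nM and 150000 nM.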

Compound 4, concentration for 50% growth inhibition: 25000 nM
The estimate for compound 4 lay 2.0-fold (0.30 log units) above the measured number; measured number inside the range.
By their numbers in this assay, from the lowest: compounds 1, 4, 2 and 3 (each within the scatter of the next).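

In this assay, 4-(methylsulfanyl)phenyl in place of 3-methylthiophen-2-yl on a double-bonded chain carbon bound to a double-bonded chain carbon gives a 2.0-fold lower number from compound 2 to compound 4 (0.30 log units; within the scatter), the only reading at this position among the compounds shown, as the earlier steps were halogen swaps on aromatic carbons. A five-membered aromatic ring with 1 hetero atom and 6 heavy atoms thus gives way to a six-membered aromatic ring of carbon only with 8 heavy atoms, and the step stays within the scatter, so this position, like the halogen swaps, separates none of the four compounds. No supporting measurement bears on this result, and the step stands as an observation without an explanation.

On these data alone, whether any change at this position can move the number beyond the scatter stays open, for example an amine or a carboxylic acid in place of the methylsulfanyl group on the phenyl ring. Also open, as far as these compounds go, is whether the step from 3-methylthiophen-2-yl to 4-(methylsulfanyl)phenyl holds when the halogens on the other two aromatic rings differ from those of compound 2.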